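Ester for ether on the shared core

The compounds below may be only part of what the source reports. "The series", "measured", "known", "first", "only" and "open" are said of these compounds alone.

compound 1 `CCOCc1c(C)coc1-c1ccc2c(c1OC)CCCC2(C)C` gives 19.8 uM
compound 2 `Cc1coc(-c2ccc3c(c2O)CCCC3)c1C(=O)O` gives 21.7 uM
compound 3 `COC(=O)c1c(C)coc1-c1ccc2c(c1OC)CCCC2(C)C` is not yet measured

In a functional assay on ZR-75-1 cells (Homo sapiens) for cytotoxicity, read by sulforhodamine B assay, with a stated time of 3 days (on this read-out lower numbers stand for an effect already at smaller amounts and higher numbers for an effect only at larger amounts of compound), compound 1 and compound 2 lie within the usual scatter of each other, so neither ranks ahead. The next comparison runs from compound 1 to compound 3: methoxycarbonyl in place of ethoxymethyl on an aromatic carbon, with methoxycarbonyl in place of ethoxymethyl on an aromatic carbon. For the measured compounds named here, no measured pair isolates this change, and the two values give no sign of a wide spread. No shift beyond the scatter is therefore expected in this assay. Compound 3 is expected at 20 uM, with a range of 8 uM to 50 uM. The estimated 1.0-fold higher number from compound 1 to compound 3 (0.00 log units; within the scatter) stays within the scatter.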

Compound 3, concentration for half-maximal effect: 34.5 uM
For compound 3 the middle estimate is 1.7-fold (0.24 log units) below the measured one; the measured number falls inside the stated range.
By their numbers in this assay, from the lowest: compounds 1, 2 and 3 (each within the scatter of the next).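

In this assay, for the compounds shown here, methoxycarbonyl in place of ethoxymethyl on this aromatic carbon gives a 1.7-fold higher number from compound 1 to compound 3 (0.24 log units; within the scatter) and is the first single-place change read at this position. On the shared core, this position therefore takes the ester as well as the ether without a shift beyond the scatter. No measurement bears on why the two groups read alike.

Going by these compounds, whether an aminomethyl group or a longer alkoxymethyl chain on this carbon would move the number beyond the scatter remains open.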